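Three Limits and One Unmeasured Acetylfuran Compound

A few compounds are considered here, and "the series" means these few. Any claim that something is new, unique, unknown or untested is made for them only; others in the source may bear on it.

In an in vitro ADME assay on microsomes from liver (Simiiformes) (on this read-out higher numbers stand for a longer-lived compound and lower numbers for a shorter-lived compound), compound 1 `CCc1cc(CCCOc2c(C)cc(-c3noc(C(F)(F)F)n3)cc2C)on1` gives > 2.5 h as a limit
Compound 2 `Cc1cc(-c2noc(C(F)(F)F)n2)cc(C)c1OCCCc1cc(CO)no1` gives > 2.5 h as a limit
Compound 3 `Cc1cc(-c2noc(C(F)(F)F)n2)cc(C)c1OCCCc1cc(CS(C)(=O)=O)no1` gives > 2.5 h as a limit

Compound 3 stands at the limit of > 2.5 h in this assay, at which 3 of the 3 values shown sit, and so has no exact number. Compound 4 `CC(=O)c1ccc(CCCOc2c(C)cc(-c3noc(C(F)(F)F)n3)cc2C)o1` carries 5-acetylfuran-2-yl in place of 3-((methylsulfonyl)methyl)-1,2-oxazol-5-yl on a saturated chain carbon, three bonds along the chain from an oxygen on an aromatic ring, as 5-acetylfuran-2-yl in place of 3-((methylsulfonyl)methyl)-1,2-oxazol-5-yl on a saturated chain carbon, three bonds along the chain from an oxygen on an aromatic ring sets out. The nearest measured changes are a step that the two limits leave unreadable from compound 1 to compound 2 and a step that the two limits leave unreadable from compound 1 to compound 3 and a step that the two limits leave unreadable from compound 2 to compound 3 and none of them swaps the whole group. They give no size or direction to carry over, so no shift beyond the scatter is expected in this assay for this change. The expected step is a step that the limit leaves unreadable from compound 3 to compound 4 and no larger. For compound 4 the estimated half-life is 3 h with 1.2 h to 6 h as its expected range.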

Compound 4, half-life: 1.05 h
Estimate against measurement, compound 4: 2.9-fold (0.46 log units) above; measured number below the stated range.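

In this assay, within the data shown here, 5-acetylfuran-2-yl at this place gives the only readable steps so far: an at least 2.3-fold lower number from compound 3 to compound 4 (0.37 log units; beyond the scatter), an at least 2.3-fold lower number from compound 2 to compound 4 (0.37 log units; beyond the scatter) and an at least 2.3-fold lower number from compound 1 to compound 4 (0.37 log units; beyond the scatter). All three 1,2-oxazol-5-yl groups shown therefore part from it on this read-out, whichever side chain they carry. The steps among compound 1, compound 2 and compound 3 still cannot be read, and those compounds have no exact number: the limit of > 2.5 h in this assay, at which 3 of the 4 values shown sit.

On these data alone, whether the acetyl group or the furan ring carries the drop stays open. A plain furan-2-yl group or a 3-acetyl-1,2-oxazol-5-yl group would separate the two.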